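This account rests on a few compounds, and the source may have more. Where it says the series, first, only, none or still open, it means among the compounds named here.

Measured so far:
compound 1 `COc1cc(-c2cc(/C=C/C(=O)c3ccc(N)cc3)[nH]n2)cc(OC)c1OC` — -78%
compound 2 `COc1ccc(C(=O)/C=C/c2cc(-c3cc(OC)c(OC)c(OC)c3)n[nH]2)cc1OC` — -75%

Working notes. Compound 2 gives -75% in a functional assay on COLO 205 cells (Homo sapiens) for cytotoxicity, read by sulforhodamine B assay, with a stated time of 48 h, tested at 100 uM; on this read-out higher numbers stand for a weaker effect at the one concentration tested and lower numbers for a stronger effect; among the two numbers recorded it is the higher, with compound 1 nearest at -78%, and the step of a number 3 percentage points higher from compound 1 to compound 2 (within the scatter) is within the scatter, so neither compound can be ranked above the other.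

Compound 3 is `COc1cc(C(=O)/C=C/c2cc(-c3cc(OC)c(OC)c(OC)c3)n[nH]2)cc(OC)c1OC` and is not yet measured. It differs from compound 2 by methoxy in place of hydrogen on an aromatic carbon. Within the data shown here, no recorded step touches that position: the only step available, a number 3 percentage points higher from compound 1 to compound 2 (within the scatter), swaps an entire aryl group and is itself within the scatter. Nothing therefore points to a move beyond the scatter in this assay in either direction, and compound 3 is expected to sit close to compound 2, with the expected step of a number 2 percentage points higher from compound 2 to compound 3 (within the scatter) essentially flat. The estimate for compound 3 is -73%, within -90% to -50%.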

Compound 3, a percentage reported as activity, at one concentration (the size of the read-out at that concentration, not a potency): -100%
Compound 3: middle estimate off by 27 percentage points, on the high side, and the stated range ends above it.
By their numbers in this assay, from the lowest: compound 3; then compounds 1 and 2 (each within the scatter of the next).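

In this assay, methoxy in place of hydrogen on an aromatic carbon, ortho to a methoxy group and meta to a large group, gives a number 25 percentage points lower from compound 2 to compound 3 (beyond the scatter) and so a stronger effect at the one concentration tested. This is the only step shown that lies beyond the scatter, whereas replacing the whole aryl group on the carbonyl carbon gave a number 3 percentage points higher from compound 1 to compound 2 (within the scatter) and separated nothing, so this aromatic ring is shown for the first time to respond to a single added group. No measurement at hand explains this response.

Whether the step belongs to methoxy itself stays open, since a hydroxyl, an ethoxy group, a chlorine atom or an amine on the same aromatic carbon is not among the compounds shown. With a single concentration behind each number, the size of the step also says nothing about potency.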